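Swapping the amino group for methoxy on the ketone-side ring

The source may hold more compounds than are shown below. What is called first, only, known or untested is meant among the compounds shown, and "the series" means these compounds.

Compound 1 `COc1cc(-c2cc(/C=C/C(=O)c3ccc(N)cc3)[nH]n2)cc(OC)c1OC` is a chalcone-like compound bearing a pyrazole. In a functional assay on HOP-62 cells (Homo sapiens) for cytotoxicity, read by sulforhodamine B assay, with a stated time of 48 h, tested at 1 uM (on this read-out lower numbers stand for a stronger effect and higher numbers for a weaker effect at the one concentration tested), compound 1 gives 86%. Its companion compound 2 `COc1ccc(-c2cc(/C=C/C(=O)c3ccc(N)cc3)[nH]n2)cc1OC` gives 92% in this assay. Within the data shown here, compound 1 has the smaller of the two numbers, but the only step measured, a number 6 percentage points higher from compound 1 to compound 2 (within the scatter), stays within the scatter, so the two compounds cannot be told apart on these numbers.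

Compound 3 `COc1ccc(C(=O)/C=C/c2cc(-c3cc(OC)c(OC)c(OC)c3)n[nH]2)cc1` differs from compound 1 by methoxy in place of amino on an aromatic carbon. Among the measured compounds shown here, no measured step touches this change; the one step available shows only that removing a methoxy group elsewhere left this assay unmoved. With nothing pointing to a shift either way, the expected step is a number 2 percentage points higher from compound 1 to compound 3 (within the scatter), no change beyond the scatter. The estimate for compound 3 in this assay is therefore 88%, with a range from 70% to 102%.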

Compound 3, a percentage reported as activity, at one concentration (the size of the read-out at that concentration, not a potency): 87%
Compound 3: middle estimate off by 1 percentage points, on the high side, within the range that was stated.
By their numbers in this assay, from the lowest: compounds 1, 3 and 2 (each within the scatter of the next).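

Among these compounds, the earlier pair varied only a methoxy group elsewhere in the molecule, so this is the first measured change on the ketone-side ring, where 4-aminophenyl becomes 4-methoxyphenyl. In this assay the exchange gives a number 1 percentage points higher from compound 1 to compound 3 (within the scatter) and shows that the amino group, with its hydrogen-bond donor, can give way to methoxy at this spot, para to a large group, with no difference these numbers can detect. No separate measurement bears on why the read-out holds steady here.

Going by these compounds, whether a different kind of group at this position, such as a carboxylic acid, a dimethylamino group or a longer alkoxy chain, would move the number remains open. On these data alone, with a single concentration, it also remains open whether amino and methoxy would separate at higher doses.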